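The compounds below may be only part of what the source reports. "The series", "measured", "known", "first", "only" and "open" are said of these compounds alone.

Measured so far in an assay on CHO cells for displacement of a labelled ligand from histamine receptor H3 (Macaca mulatta); on this read-out higher numbers stand for weaker inhibition and lower numbers for stronger inhibition:

- compound 1, `Cc1cc(NC(=O)C2CC3CCC2C3)ccc1N1CCC(N2CCCC2C)C1`, 130 nM
- compound 2, `Cc1cc(N2CCC(N3CCCC3C)C2)ccc1NC(=O)C1CCCO1`, 7.34 nM

Compound 1 has the highest number of the two, and the gap to compound 2 is beyond the scatter; compound 2 thus stands as the stronger inhibitor here. Compound 2 also carries the oxolan-2-yl amide, though on a core that is not the same as that of compound 1, so its value can only be read as a hint of what this amide tolerates, not as a direct step.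

Compound 3, `Cc1cc(NC(=O)C2CCCO2)ccc1N1CCC(N2CCCC2C)C1`, is not yet measured. It keeps the core of compound 1 and changes only the amide: a group of 5 heavy atoms (4 carbon, 1 oxygen; one five-membered non-aromatic ring with 1 hetero atom) in place of a group of 7 heavy atoms (7 carbon; 2 five-membered non-aromatic rings of carbon only), on a carbonyl carbon.

Among the measured compounds shown here, the only guide is that compound 2, which carries the entering group, gives 7.34 nM while compound 1 gives 130 nM. On that basis a step toward a lower number, beyond the scatter, is expected for compound 3, namely an 8.7-fold lower number from compound 1 to compound 3 (0.94 log units; beyond the scatter). Compound 3 is therefore estimated at 15 nM, with a range from 4 nM to 60 nM.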

Compound 3, inhibition constant: 17 nM
Compound 3: the middle estimate sits 1.1-fold (0.05 log units) below what was measured; the range from low to high includes it.
By their numbers in this assay, from the lowest: compound 2; then compound 3; then compound 1.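

In this assay, the group on the carbonyl carbon of the core of compound 1 now has a direct reading: putting oxolan-2-yl in place of the group of 7 heavy atoms gives a 7.6-fold lower number from compound 1 to compound 3 (0.88 log units; beyond the scatter), so this position responds to the change of amide and accepts the oxolan-2-yl ring. The change alters several things at once, going from 7 heavy atoms, all carbon, to 5 heavy atoms, from 2 five-membered non-aromatic rings of carbon only to one with 1 hetero atom, and from 0 hydrogen-bond acceptors to 1, and this single step cannot assign the shift to any one of them. No measurement at hand speaks to why the number moves.

Still open, as far as these compounds go, is whether the ring oxygen of oxolan-2-yl or the lower heavy-atom count goes with the lower number, a question that a cyclopentyl group on the same carbonyl carbon would address. Also open, from the compounds shown here alone, is how far the position reaches beyond these two groups, for instance to a pyrrolidin-2-yl ring carrying an amine or to an open chain such as n-butyl.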